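From Chloro to Methoxy on the Shared Core

The source may report more compounds than this note shows. Statements on the series, on what has been measured and on what is new or still open speak of the compounds shown alone.

Four compounds share one core: compound 1 (`COc1cccc(Sc2cccc(N)c2C#N)c1`), compound 2 (`Cc1cc(C)cc(Sc2cccc(N)c2C#N)c1`), compound 3 (`Cc1cc(Cl)cc(Sc2cccc(N)c2C#N)c1`) and compound 4 (`COc1cc(C)cc(Sc2cccc(N)c2C#N)c1`). Within the data shown here, in a functional assay on MT4 cells (Homo sapiens) for cytotoxicity (a lower number here means a stronger inhibitor, a higher number a weaker inhibitor), compound 3 gives 16000 nM, the only actual number among the three measured compounds. Compound 1 is reported only as a limit, > 200000 nM. Compound 2 is also reported only as a limit, > 2000 nM.

Compound 4 has not yet been measured. It differs from compound 3 by methoxy in place of chloro on an aromatic carbon.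

The measured data offer little guidance on the size of this change. Among the measured compounds shown here, the one measured step, a step that the limit leaves unreadable from compound 2 to compound 3, concerns a different exchange and has no readable size. Methoxy also stands on compound 1, whose > 200000 nM is a limit, and this points only loosely towards the weaker side. A modest expected move in that direction is therefore assumed, with the estimated step being a 1.9-fold higher number from compound 3 to compound 4 (0.27 log units; within the scatter). The assay may again report only a limit. For compound 4 the estimated value in this assay is 30000 nM, with an expected range from 8000 nM to 120000 nM.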

Compound 4, half-maximal inhibitory concentration: 10000 nM
Compound 4: middle estimate off by 3.0-fold (0.48 log units), on the high side; the range from low to high includes it.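

In this assay, methoxy in place of chloro on an aromatic carbon, meta to a methyl group, gives a 1.6-fold lower number from compound 3 to compound 4 (0.20 log units; within the scatter), so at this position the data do not separate the two groups. The added methyl tells a different story: with methoxy present in both compounds, methyl in place of hydrogen on an aromatic carbon gives an at least 20-fold lower number from compound 1 to compound 4 (1.30 log units; beyond the scatter), a large step and the only readable one here that lies beyond the scatter, although it starts from a limit and not from a number. The step between compound 2 and compound 4, methoxy in place of methyl, cannot be read, because its starting point is only a limit: the limit of > 2000 nM in this assay, at which 1 of the 4 values shown sits.

The compounds shown leave open whether an amine, a carboxylic acid or a longer chain such as ethoxy in this place would read differently from chloro and methoxy. Going by these compounds, compound 1 is known only as a limit, so the full size of its step also remains open.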